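The source may hold more compounds than are shown below. What is called first, only, known or untested is meant among the compounds shown, and "the series" means these compounds.

Three compounds share one core, and they differ only in the group attached to an amide-type nitrogen. Compound 1 `C=C(CC)C(=O)c1ccc(OCC(=O)Nc2nc3ccccc3s2)c(Cl)c1Cl` carries a 1,3-benzothiazol-2-yl group there. In a functional assay on CLL cells (Homo sapiens) for cytotoxicity, read by MTT assay, with a stated time of 48 h (a higher number here means that more compound is needed for the effect, a lower number that less compound is needed), compound 1 gives 1500 nM, the lowest of the two numbers recorded. Compound 3 `C=C(CC)C(=O)c1ccc(OCC(=O)NC2CCN(CC(=O)OC)CC2)c(Cl)c1Cl`, with a different group on that nitrogen, gives 10600 nM in this assay, a gap from compound 1 that lies beyond the usual scatter. Compound 2 `C=C(CC)C(=O)c1ccc(OCC(=O)Nc2nc(/C(=N\OC)C(=O)O)cs2)c(Cl)c1Cl` gives no number in this assay but only a limit, > 25000 nM; this is the limit of > 25000 nM in this assay, at which 1 of the 3 values shown sits.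

Compound 4 `C=C(CC)C(=O)c1ccc(OCC(=O)NO)c(Cl)c1Cl` has not yet been measured. Relative to compound 1 the change is hydroxy in place of 1,3-benzothiazol-2-yl on an amide-type nitrogen. The two-ring aromatic piece leaves and a single small hydroxy group takes its place. Among the measured compounds, every departure from the 1,3-benzothiazol-2-yl group has gone with a higher number: compound 3 rose well beyond the scatter, and compound 2 reached only a limit. On that basis the step of a 4.7-fold higher number from compound 1 to compound 4 (0.67 log units; beyond the scatter) is expected to be an increase, beyond the scatter. For compound 4 the estimate in this assay is 7000 nM, with a likely range from 1500 nM to 25000 nM.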

Compound 4, half-maximal effective concentration: 4500 nM
For compound 4 the middle estimate is 1.6-fold (0.19 log units) above the measured one, and the stated range covers the measured number.
By their numbers in this assay, from the lowest: compound 1; then compound 4; then compound 3. At a limit, above all of these: compound 2.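

In this assay, replacing the 1,3-benzothiazol-2-yl group with hydroxy on this amide-type nitrogen gives a 3.0-fold higher number from compound 1 to compound 4 (0.48 log units; beyond the scatter), so the two-ring aromatic piece is not needed for a measurable number here, although compound 1 keeps the lowest number of the series. The much smaller hydroxy group also leaves compound 4 lower than compound 3, which gives 10600 nM, so among these compounds a departure from the 1,3-benzothiazol-2-yl group can cost little or much, depending on what replaces it. Compound 2 remains a limit of the assay, at > 25000 nM.

The compounds shown give no measured property that accounts for the step from benzothiazolyl to hydroxy. Within the data shown here, it remains open whether a methoxy group, which keeps the oxygen on this nitrogen but has no hydroxy hydrogen, or a single phenyl ring, which keeps only one aromatic ring, would fall nearer to compound 1 or to compound 4.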